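Compound 3 to compound 4: aryl on the acid side chain

The source may report more compounds than this note shows. Statements on the series, on what has been measured and on what is new or still open speak of the compounds shown alone.

Measured in a functional assay on DU-145 cells (Homo sapiens) for cytotoxicity, read by trypan blue exclusion, with a stated time of 96 h; a higher number here means a weaker inhibitor, a lower number a stronger inhibitor:
- compound 1 `COC(=O)C(C)Nc1cc(NS(=O)(=O)/C=C/c2c(OC)cc(OC)cc2OC)ccc1OC`: 100 nM
- compound 2 `COc1cc(OC)c(/C=C/S(=O)(=O)Nc2ccc(OC)c(NC(C)C(=O)O)c2)c(OC)c1`: 40 nM
- compound 3 `COc1cc(OC)c(/C=C/S(=O)(=O)Nc2ccc(OC)c(NC(C)(C)C(=O)O)c2)c(OC)c1`: 70 nM

Compound 3, at 70 nM, cannot be separated from either of the other two: a 1.4-fold lower number from compound 1 to compound 3 (0.15 log units; within the scatter), and a 1.8-fold higher number from compound 2 to compound 3 (0.24 log units; within the scatter). The next structure, compound 4 `COc1cc(OC)c(/C=C/S(=O)(=O)Nc2ccc(OC)c(NC(C(=O)O)c3ccc(F)cc3)c2)c(OC)c1`, differs from it as follows: carboxy(4-fluorophenyl)methyl in place of 1-carboxy-1-methylethyl on a nitrogen on an aromatic ring. In words, carboxy(4-fluorophenyl)methyl stands in place of 1-carboxy-1-methylethyl on a nitrogen on an aromatic ring.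

For the measured compounds named here, no measured step brings an aromatic ring into this substituent, so the data give no direct size for the change. The nearest guide is a 1.8-fold higher number from compound 2 to compound 3 (0.24 log units; within the scatter), a change on the same substituent. Going by the values given here, the only step beyond the scatter is a 2.5-fold lower number from compound 1 to compound 2 (0.40 log units; beyond the scatter), which is modest and ends at a carboxy compound, and compound 3 and compound 4 both already carry that group. In this assay the expected result is a 1.1-fold higher number from compound 3 to compound 4 (0.06 log units; within the scatter), with no shift beyond the scatter anticipated, though with wide uncertainty. The estimate for compound 4 is 80 nM, with an expected range of 30 nM to 250 nM.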

Compound 4, half-maximal inhibitory concentration: 75 nM
Compound 4: middle estimate off by 1.1-fold (0.03 log units), on the high side; measured number inside the range.
By their numbers in this assay, from the lowest: compounds 2, 3, 4 and 1 (each within the scatter of the next, the first and the last beyond it).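

In this assay, for the compounds shown here, an aromatic ring enters this substituent for the first time, with 11 heavy atoms in carboxy(4-fluorophenyl)methyl against 6 in 1-carboxy-1-methylethyl, and the number on the nitrogen-bound group does not move outside the scatter (a 1.1-fold higher number from compound 3 to compound 4 (0.03 log units; within the scatter)). The comparisons with the two smaller substituents read the same way (a 1.9-fold higher number from compound 2 to compound 4 (0.27 log units; within the scatter); a 1.3-fold lower number from compound 1 to compound 4 (0.12 log units; within the scatter)), so among the compounds shown this position carries a 4-fluorophenyl group as readily as a methyl group, with no step here beyond the scatter. Nothing measured on these compounds bears on the reason for this result.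

Open, on these data alone, is whether a plain phenyl group without fluorine, a longer chain or a pyridine ring at this carbon would keep the number in the same range. Also open, as far as these compounds go, is whether an amine in place of the carboxylic acid on this substituent would do so.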